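The source may report more compounds than this note shows. Statements on the series, on what has been measured and on what is new or still open speak of the compounds shown alone.

Compounds measured so far in an ADME assay on HCT-116 cells (Homo sapiens) for cytotoxicity, read by CellTiter-Glo, with a stated time of 72 h; on this read-out higher numbers stand for weaker inhibition and lower numbers for stronger inhibition:
compound 1, `CC1CCN(C2CCN(S(=O)(=O)c3cccc(N)c3)CC2)CC1`: > 5000 nM
compound 2, `COc1cccc(S(=O)(=O)N2CCC(N3CCC(C)CC3)CC2)c1`: > 5000 nM

In this assay compound 1 gives > 5000 nM, which is a limit of the assay rather than a number. Compound 2 gives > 5000 nM, likewise a limit and not a number. Going by the values given here, the one measured step, a step that the two limits leave unreadable from compound 1 to compound 2, is methoxy in place of amino on an aromatic carbon, and its size cannot be read because the limit of > 5000 nM in this assay, at which 2 of the 2 values shown sit, is where both of its ends sit. Compound 2 therefore stands at the limit, with no measured neighbour that places it at a number.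

Compound 3, `CC1CCN(C2CCN(S(=O)(=O)c3ccc(Cl)c(Cl)c3)CC2)CC1`, has not yet been measured in this assay. It differs from compound 2 by 3,4-dichlorophenyl in place of 3-methoxyphenyl on a sulfonyl sulfur. Among the compounds with values here, no measured step touches this part of the molecule, and the only step that exists is unreadable, so nothing measured fixes a direction or a size for the change. Compound 3 is expected to give about 5000 nM, within 1500 nM to 20000 nM, and most probably to be reported as a limit again. The step expected from this estimate, a number no higher from compound 2 to compound 3 (the limit leaves the size open), is none beyond the scatter.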

Compound 3, half-maximal inhibitory concentration: > 5000 nM
Compound 3: no number, only a limit (the forecaster's own chance of this, stated with the estimate: 65%); the middle value lies on the limit itself.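

Compound 3 also gives a limit rather than a number, so its steps to compound 1 and compound 2 cannot be read, because all three compounds sit at the same limit: the limit of > 5000 nM in this assay, at which 3 of the 3 values shown sit.

The compounds shown leave open what number each would give, and whether exchanging the 3-aminophenyl, 3-methoxyphenyl and 3,4-dichlorophenyl groups on the sulfonyl sulfur changes that number at all.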